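Swapping the indole-derived acyl group on the longer-chain amide

A few compounds are considered here, and "the series" means these few. Any claim that something is new, unique, unknown or untested is made for them only; others in the source may bear on it.

Three threonine-derived amides have been tested in a functional assay on SiHa cells (Homo sapiens) for cytotoxicity, read by MTT assay, with a stated time of 48 h; a higher number here means a weaker inhibitor, a lower number a stronger inhibitor. Compound 1 `CCCCCCCCCCCCCCNC(=O)[C@@H](NC(=O)c1cc2ccccc2n1C)[C@@H](C)O` gives 26500 nM in this assay. Compound 2 `CCCCCCCCCCCCCCNC(=O)[C@@H](NC(=O)/C=C/c1ccccc1)[C@@H](C)O` carries the change 2-phenylethenyl in place of 1-methyl-1H-indol-2-yl on a carbonyl carbon and gives 35800 nM; the step of a 1.4-fold higher number from compound 1 to compound 2 (0.13 log units; within the scatter) lies within the scatter. Compound 3 `CCCCCCCCCCCCCCCCCCNC(=O)[C@@H](NC(=O)c1cc2ccccc2n1C)[C@@H](C)O` differs from compound 1 by butyl in place of hydrogen on a saturated chain carbon, ten or more bonds along the chain from an amide-type nitrogen. In this assay compound 3 gives 113000 nM, a step of a 4.3-fold higher number from compound 1 to compound 3 (0.63 log units; beyond the scatter) that stands beyond the scatter, so that compound 3 gives the highest number of the three.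

Compound 4 `CCCCCCCCCCCCCCCCCCNC(=O)[C@@H](NC(=O)/C=C/c1ccccc1)[C@@H](C)O` remains to be measured. It arises from compound 3 by 2-phenylethenyl in place of 1-methyl-1H-indol-2-yl on a carbonyl carbon, the same change that turns compound 1 into compound 2, made on the core bearing the butyl extension. Since that change cost only a 1.4-fold higher number from compound 1 to compound 2 (0.13 log units; within the scatter), a similarly small step is expected here, and the expected step is a 1.4-fold higher number from compound 3 to compound 4 (0.15 log units; within the scatter). Because compound 3 already gives 113000 nM, compound 4 is expected to give 160000 nM in this assay, between 70000 nM and 380000 nM.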

Compound 4, half-maximal inhibitory concentration: 35900 nM
Beside the measured number, compound 4's estimate is 4.5-fold (0.65 log units) above it, outside the stated range (below it).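

In this assay, 2-phenylethenyl in place of 1-methyl-1H-indol-2-yl on a carbonyl carbon gives a 3.1-fold lower number from compound 3 to compound 4 (0.50 log units; beyond the scatter), so the change does not carry over from the core of compound 1 to the core of compound 3 with the same outcome: the same change on two cores in this assay, a 1.4-fold higher number (0.13 log units; within the scatter) from compound 1 to compound 2 and a 3.1-fold lower number (0.50 log units; beyond the scatter) from compound 3 to compound 4, 4.3-fold (0.63 log units) apart, beyond the scatter of two such steps Read the other way, butyl in place of hydrogen on the saturated chain gives a 1.0-fold higher number from compound 2 to compound 4 (0.00 log units; within the scatter), and this change also depends on the core that carries it: the same change on two cores in this assay, a 4.3-fold higher number (0.63 log units; beyond the scatter) from compound 1 to compound 3 and a 1.0-fold higher number (0.00 log units; within the scatter) from compound 2 to compound 4, 4.3-fold (0.63 log units) apart, beyond the scatter of two such steps The four compounds therefore show that the two changes do not add independently in this set, but they rest on a single square of compounds and do not show why the steps differ or how either change would behave on any other core.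

From the compounds shown here alone, it remains open whether the same dependence would appear with a longer chain or an intermediate chain. An acyl group carrying an amine or a carboxylic acid also remains untested within the compounds shown here.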